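Cycloalkyl amide variation on the shared core

This account rests on a few compounds, and the source may have more. Where it says the series, first, only, none or still open, it means among the compounds named here.

Measured in an assay on HEK293 cells for positive allosteric modulation of metabotropic glutamate receptor 5 (Homo sapiens), read by FLIPR, with a stated time of 1 h; on this read-out lower numbers stand for an effect already at smaller amounts and higher numbers for an effect only at larger amounts of compound:
compound 1 `O=C(C1CCC1)N1CCc2nc(C#Cc3ccccc3)sc2C1`, a limit of the assay: > 10000 nM
compound 2 `O=C(C1CC(F)C1)N1CCc2nc(C#Cc3ccccc3)sc2C1`: 85 nM
compound 3 `COC1CC(C(=O)N2CCc3nc(C#Cc4ccccc4)sc3C2)C1`: 640 nM

Compound 3 stands at the highest of the two measured numbers; the nearest step is a 7.5-fold higher number from compound 2 to compound 3 (0.88 log units; beyond the scatter). Compound 4 `CC1CCCC(C(=O)N2CCc3nc(C#Cc4ccccc4)sc3C2)C1` carries 3-methylcyclohexyl in place of 3-methoxycyclobutyl on a carbonyl carbon. The measured steps all vary the substituent on the cyclobutyl ring: an at least 110-fold lower number from compound 1 to compound 2 (2.07 log units; beyond the scatter) and an at least 15-fold lower number from compound 1 to compound 3 (1.19 log units; beyond the scatter), with a 7.5-fold higher number from compound 2 to compound 3 (0.88 log units; beyond the scatter) between the two substituted members. None changes ring size, so this step is not covered directly. Compound 4 carries neither fluoro nor methoxy. Compound 1, which also lacks both, sits at the limit of > 10000 nM in this assay, at which 1 of the 3 values shown sits. The number for compound 4 is therefore expected to rise, a 4.7-fold higher number from compound 3 to compound 4 (0.67 log units; beyond the scatter), with a real chance of only a limit. The estimate for compound 4 is 3000 nM, between 600 nM and 20000 nM.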

Compound 4, half-maximal effective concentration: 100 nM
Compound 4: the middle estimate sits 30-fold (1.48 log units) above what was measured; the measured number lies below the stated range.
By their numbers in this assay, from the lowest: compounds 2 and 4 (each within the scatter of the next); then compound 3. At a limit, above all of these: compound 1.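

Neither fluoro nor methoxy is needed for a low number at this carbonyl carbon: 3-methylcyclohexyl gives a 6.4-fold lower number from compound 3 to compound 4 (0.81 log units; beyond the scatter) and an at least 100-fold lower number from compound 1 to compound 4 (2.00 log units; beyond the scatter). Set against 3-fluorocyclobutyl, the same group gives a 1.2-fold higher number from compound 2 to compound 4 (0.07 log units; within the scatter), so a larger ring with a methyl group matches the fluoro member. Compound 1 remains a limit, the only one in the set: the limit of > 10000 nM in this assay, at which 1 of the 4 values shown sits.

Compound 4 alters ring size and substituent at once, so plain cyclohexyl and 3-methylcyclobutyl would be needed to separate the two. Also open, going by these compounds, is how an amine or a carboxylic acid on the ring would read.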